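This account rests on a few compounds, and the source may have more. Where it says the series, first, only, none or still open, it means among the compounds named here.

Compound 1 `Cn1ccc(-c2cccc3c2CCC3c2ncc[nH]2)n1` was tested in a functional assay on CHO cells for agonist activity at Alpha-1D adrenergic receptor (Homo sapiens), read by FLIPR and calcium flux; a lower number here means that less compound is needed, a higher number that more compound is needed for the effect. In this assay compound 1 gives > 10000 nM, which is a limit of the assay rather than a number. A second measured compound, compound 2 `Clc1ccc2c(c1-c1ccn[nH]1)CCC2c1ncc[nH]1`, belongs to the same series. In this assay compound 2 gives > 10000 nM, again a limit and not a number. Going by the values given here, both measured values therefore sit at the limit of > 10000 nM in this assay, at which 2 of the 2 values shown sit, so compound 1 stands at the same limit as the only other measured compound, and no step between measured compounds can be drawn from them. Compound 3 `CNC(=O)c1cccc2c1CCC2c1ncc[nH]1` has not yet been measured. It differs from compound 1 by methylcarbamoyl in place of 1-methyl-1H-pyrazol-3-yl on an aromatic carbon. Among the compounds with values here, with only limits known, there is no measured step to set the size of the change in this assay, and any direction remains open. Compound 3 is expected to give 6000 nM, within 800 nM to 30000 nM. The step is expected to be an at least 1.6-fold lower number from compound 1 to compound 3 (0.22 log units; that floor lies within the scatter), with a real chance that only a limit is reported again.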

Compound 3, half-maximal effective concentration: > 10000 nM
Compound 3 was reported as a limit; the forecaster's own chance of this, stated with the estimate: 55%; middle value at least 1.6-fold (0.22 log units) from the limit.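

Compound 1 and compound 3 are both reported only as limits, so no step between them can be read in this assay: the limit of > 10000 nM in this assay, at which 3 of the 3 values shown sit.

The compounds shown leave open how far each lies beyond that limit, and whether any group on this aromatic carbon of the shared core would give a measurable value.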